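A Methyl on the Saturated Ring Carbon

The source may report more compounds than this note shows. Statements on the series, on what has been measured and on what is new or still open speak of the compounds shown alone.

Of the compounds shown here, two of the shared core have been measured. In a functional assay on A549 cells (Homo sapiens) for antiproliferative activity, with a stated time of 5 days (a higher number here means a weaker inhibitor, a lower number a stronger inhibitor), compound 1 `CC1OC2(C=CC(=O)C=C2)N(c2nc(-c3cccc4ccccc34)nn2-c2ccccc2)C1=O` gives 180 nM, and compound 2 `O=C1C=CC2(C=C1)OCC(=O)N2c1nc(-c2ccc3ccccc3c2)nn1-c1ccccc1` gives 140 nM, a number that stands within the scatter of compound 1. Compound 3 `CC1OC2(C=CC(=O)C=C2)N(c2nc(-c3ccc4ccccc4c3)nn2-c2ccccc2)C1=O` differs from compound 2 only by methyl in place of hydrogen on a saturated ring carbon. Within the data shown here, no measured pair isolates this change, so no step of known size can be drawn for it. The step is expected to be a 1.1-fold higher number from compound 2 to compound 3 (0.03 log units; within the scatter), no larger than the scatter in either direction. Compound 3 is estimated in this assay at 150 nM, between 60 nM and 400 nM.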

Compound 3, half-maximal inhibitory concentration: 310 nM
Estimate against measurement, compound 3: 2.1-fold (0.32 log units) below; low and high end bracket the measured number.
By their numbers in this assay, from the lowest: compounds 2, 1 and 3 (each within the scatter of the next, the first and the last beyond it).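

In this assay methyl in place of hydrogen on the saturated ring carbon, with naphthalen-2-yl on the aromatic carbon, gives a 2.2-fold higher number from compound 2 to compound 3 (0.35 log units; beyond the scatter) and so is a modest but readable step at this position. Naphthalen-2-yl in place of naphthalen-1-yl, with the methyl present, gives a 1.7-fold higher number from compound 1 to compound 3 (0.24 log units; within the scatter) and so cannot be told apart from scatter. No measurement at hand offers a reason for the methyl step. On these data alone, what an ethyl or a hydroxymethyl group would do on this carbon stays open, as does the size of the methyl step with naphthalen-1-yl in place.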